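A few compounds are considered here, and "the series" means these few. Any claim that something is new, unique, unknown or untested is made for them only; others in the source may bear on it.

Measured so far in an ADME assay on HCT-116 cells (Homo sapiens) for cytotoxicity, read by MTT assay, with a stated time of 11 days; on this read-out higher numbers stand for weaker inhibition of growth and lower numbers for stronger inhibition of growth:

Compound 1 `CCCCCc1cc2c(=O)n(CC3CC3)cnc2s1`. In this assay compound 1 gives only a limit, > 100 ug/mL, and no number.
Compound 2 `CCCCCCc1cc2c(=O)n(CC3CC3)cnc2s1`. In this assay compound 2 gives 17.6 ug/mL.
Compound 3 `CCCCCCc1cc2c(=O)n(CCN=[N+]=[N-])cnc2s1`. In this assay compound 3 gives 14.7 ug/mL.

Compound 4 `CCCCCCCc1cc2c(=O)n(CCN=[N+]=[N-])cnc2s1` has not yet been measured in this assay.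

From compound 1 to compound 2 the change is methyl in place of hydrogen on a saturated chain carbon, five bonds along the chain from an aromatic carbon, and it brings an at least 5.6-fold lower number from compound 1 to compound 2 (0.75 log units; beyond the scatter). The size of that step is bounded only from one side, since the value of compound 1 is a limit, (the limit of > 100 ug/mL in this assay, at which 1 of the 3 values shown sits). From compound 2 to compound 3 the change is azidomethyl in place of cyclopropyl on a saturated chain carbon bound to an aromatic nitrogen, with a 1.2-fold lower number from compound 2 to compound 3 (0.08 log units; within the scatter); the two values of compound 2 and compound 3 are within the scatter of each other. The difference between the core of compound 1 and the core of compound 3 is not broken down here.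

From compound 3 to compound 4 the change is methyl in place of hydrogen on a saturated chain carbon, six bonds along the chain from an aromatic carbon. Among the measured compounds shown here, it is the same kind of change as the one from compound 1 to compound 2, but not the same: there the place is five bonds along the chain from an aromatic carbon, here six bonds along the chain from an aromatic carbon. For the measured compounds named here, only one such step is known, and it is a lower bound. For compound 4 the expected step is a 1.8-fold lower number from compound 3 to compound 4 (0.26 log units; within the scatter), smaller than an at least 5.6-fold lower number from compound 1 to compound 2 (0.75 log units; beyond the scatter), which rests on compound 1 being a limit rather than a number. Compound 4 is estimated at 8 ug/mL, between 3 ug/mL and 25 ug/mL.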

Compound 4, concentration for 50% growth inhibition: > 100 ug/mL
Compound 4: only a limit was reported (the forecaster's own chance of this, stated with the estimate: 5%); middle value at least 12-fold (1.09 log units) away from the limit.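

In this assay compound 4 gives only a limit, > 100 ug/mL, and not a number. On the core of compound 3, methyl in place of hydrogen on a saturated chain carbon, six bonds along the chain from an aromatic carbon, brings an at least 6.8-fold higher number from compound 3 to compound 4 (0.83 log units; beyond the scatter), so extending the chain by this change does not carry over from one core to the other with the same direction of effect: the same change on two cores in this assay, an at least 5.6-fold lower number (0.75 log units; beyond the scatter) from compound 1 to compound 2 and an at least 6.8-fold higher number (0.83 log units; beyond the scatter) from compound 3 to compound 4, at least 38-fold (1.58 log units) apart, beyond the scatter of two such steps This does not show whether the core or the place on the chain governs the difference, as the earlier step sits five bonds along the chain and the later one six, and neither step has an exact size: the limit of > 100 ug/mL in this assay, at which 2 of the 4 values shown sit.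

Open, as far as these compounds go, is how the core of compound 2 responds to a longer chain and how the core of compound 3 responds to a shorter chain, either of which would put both places on a single core. Also open, from the compounds shown here alone, is whether the chain of compound 3 tolerates an amine or a carboxylic acid in place of the azide, and whether a still longer chain on either core stays at the limit.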